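A longer hydroxamic acid chain on compound 1

The source may report more compounds than this note shows. Statements on the series, on what has been measured and on what is new or still open speak of the compounds shown alone.

Measured so far in a functional assay on MCF7 cells (Homo sapiens) for inhibition, read by MTT assay, with a stated time of 72 h; on this read-out higher numbers stand for weaker inhibition and lower numbers for stronger inhibition
Compound 1 `COc1cc2c(Oc3ccc(NC(=O)c4nn(-c5ccccc5C)cc(C)c4=O)cc3)ccnc2cc1OCC(=O)NO` gives 8780 nM
Compound 2 `COc1cc2c(Oc3ccc(NC(=O)c4nn(-c5ccccc5)ccc4=O)cc3)ccnc2cc1OCCCC(=O)NO` gives 7410 nM

Compound 1 and compound 2 lie within the usual scatter of each other in this assay and so cannot be ranked. Among the measured compounds shown here, compound 1 therefore stands level with the only other measured compound. Compound 3 `COc1cc2c(Oc3ccc(NC(=O)c4nn(-c5ccccc5C)cc(C)c4=O)cc3)ccnc2cc1OCCCCCCC(=O)NO` differs from compound 1 in one place, on a saturated chain carbon bound to an oxygen on an aromatic ring, where 5-(hydroxycarbamoyl)pentyl takes the place of hydroxycarbamoyl (5-(hydroxycarbamoyl)pentyl in place of hydroxycarbamoyl on a saturated chain carbon bound to an oxygen on an aromatic ring).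

For the measured compounds named here, no measured pair isolates this kind of change. Compound 2 (7410 nM) differs from compound 1 in more than one place, so it offers no clean comparison. The forecast is therefore a cautious judgement based on the longer chain alone, with little direct support from the data. In this assay the expected change is a 2.9-fold lower number from compound 1 to compound 3 (0.47 log units; beyond the scatter) toward stronger inhibition, moderate in size and quite uncertain. For compound 3 the estimate is 3000 nM (expected range 600 nM to 12000 nM).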

Compound 3, half-maximal inhibitory concentration: 1830 nM
The estimate for compound 3 lay 1.6-fold (0.21 log units) above the measured number, and the stated range covers the measured number.
By their numbers in this assay, from the lowest: compound 3; then compounds 2 and 1 (each within the scatter of the next).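

In this assay, putting 5-(hydroxycarbamoyl)pentyl in place of hydroxycarbamoyl on a saturated chain carbon bound to an oxygen on an aromatic ring gives a 4.8-fold lower number from compound 1 to compound 3 (0.68 log units; beyond the scatter), a modest step toward stronger inhibition that lies beyond the usual scatter. Among the compounds shown here, this is the first clean reading at this position: the rest of the molecule stays the same, so the change in the number can be tied to this one change, whereas compound 2 differs from compound 1 in more than one place and could not show this. Nothing available accounts for the gain, so it stands as an observation without an explanation.

From the compounds shown here alone, a single step between two compounds gives no trend with chain length, so it remains open whether a chain longer than 5-(hydroxycarbamoyl)pentyl would push the number lower still or reverse the gain. Going by these compounds, it is also open whether the hydroxamic acid end itself matters, which a carboxylic acid or an amine at the end of the same chain would begin to test.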